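Adding Chloro to a Compound Already at the Limit

The compounds below may be only part of what the source reports. "The series", "measured", "known", "first", "only" and "open" are said of these compounds alone.

The parent of this small set, compound 1 `O=C(/C=C/C=C/c1ccccc1)c1ccccc1`, was tested in an ADME assay on RAW264.7 cells (Mus musculus) for cytotoxicity, read by MTT assay (a higher number here means a weaker inhibitor, a lower number a stronger inhibitor), and gave 44300 nM. Compound 2 `COc1ccc(C(=O)/C=C/C=C/c2ccccc2)cc1` carries a methoxy in place of hydrogen on an aromatic carbon. In this assay compound 2 gives > 100000 nM, which is a limit of the assay and not a number. The step of an at least 2.2-fold higher number from compound 1 to compound 2 (0.35 log units; beyond the scatter) is therefore only a lower bound, since compound 2 sits at the limit of > 100000 nM in this assay, at which 1 of the 3 values shown sits. Compound 3 `O=C(/C=C/C=C/c1ccccc1)c1ccc(F)cc1` has no result in this assay; for compound 3 the entry is "not determined" (no result reported). Among the values shown, compound 2 thus stands at the top of the range, without a single number of its own.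

Compound 4 `COc1ccc(C(=O)/C=C/C=C/c2ccc(Cl)cc2)cc1` differs from compound 2 in one place (chloro in place of hydrogen on an aromatic carbon). Among the measured compounds shown here, no measured step concerns a chloro group; the only measured step, an at least 2.2-fold higher number from compound 1 to compound 2 (0.35 log units; beyond the scatter), concerns a methoxy group and shows a move toward weaker inhibition that ended at the limit. Nothing among the shown values suggests that the chloro group would pull the number back down. The expected step is a number no higher from compound 2 to compound 4 (the limit leaves the size open), none beyond the scatter. Compound 4 is expected to give 100000 nM in this assay, with a range from 40000 nM to 300000 nM, and quite possibly again only a limit.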

Compound 4, half-maximal inhibitory concentration: 80200 nM
Beside the measured number, compound 4's estimate is 1.2-fold (0.10 log units) above it, within the range that was stated.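

Among the compounds shown here, compound 4 is the first compound with the methoxy group to give a single number in this assay, so the change from phenyl to 4-chlorophenyl places a measured value on this side of the molecule for the first time. On these data alone, the step (an at least 1.2-fold lower number from compound 2 to compound 4 (0.09 log units; that floor lies within the scatter)) gives only a floor, and its true size stays open because compound 2 has no number of its own: (the limit of > 100000 nM in this assay, at which 1 of the 4 values shown sits). The result therefore shows that chloro at this place, para to a large group, is compatible with a measurable number in this series, but it does not show that chloro lowers the number beyond the scatter.

The compounds shown leave open what chloro does on the core of compound 1 without the methoxy group, and whether an amine or a carboxylic acid in the same place would give a single number in this assay as well. Any step involving compound 3, the fluoro compound, cannot be read, so the comparison between the two halogens also remains open.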